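Replacing piperidin-4-yl with 2,2-diethoxyethyl on compound 1

This account rests on a few compounds, and the source may have more. Where it says the series, first, only, none or still open, it means among the compounds named here.

Values measured in a functional assay on MDA-MB-231 cells (Homo sapiens) for inhibition, read by MTT assay, with a stated time of 72 h; a lower number here means a stronger inhibitor, a higher number a weaker inhibitor:
- Compound 1 `CC(C)=CCC[C@H](C)c1ccc(C)c(CNCC2CCNCC2)c1O`: 18300 nM
- Compound 2 `CC(C)=CCC[C@H](C)c1ccc(C)c2c1OCN(CCCCCO)C2`: 5400 nM
- Compound 3 `CC(C)=CCC[C@H](C)c1ccc(C)c2c1OCN(CCCCC(=O)O)C2`: > 50000 nM, a limit of the assay

Of the two exact numbers, compound 1 holds the higher one, and compound 2 lies lower by a gap beyond the scatter. The next compound, compound 4 `CCOC(CCNCc1c(C)ccc([C@@H](C)CCC=C(C)C)c1O)OCC`, keeps the core of compound 1 and changes only its side chain 2,2-diethoxyethyl in place of piperidin-4-yl on a saturated chain carbon bound to an amine nitrogen: 2,2-diethoxyethyl stands in place of piperidin-4-yl on a saturated chain carbon bound to an amine nitrogen.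

Within the data shown here, only one measured step is available, an at least 9.2-fold higher number from compound 2 to compound 3 (0.96 log units; beyond the scatter). It lies beyond the scatter, but it puts carboxy in place of hydroxymethyl, a change that compound 4 does not make, so it bears only loosely on this case. Among the measured compounds shown here, no measured step matches the exchange, so no step beyond the scatter is expected in this assay, and the estimated change is a 1.4-fold lower number from compound 1 to compound 4 (0.15 log units; within the scatter). For compound 4 the expected value is 13000 nM, with an estimated range of 4500 nM to 38000 nM.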

Compound 4, half-maximal inhibitory concentration: 14900 nM
Compound 4: the middle estimate sits 1.1-fold (0.06 log units) below what was measured, and the stated range covers the measured number.
By their numbers in this assay, from the lowest: compound 2; then compounds 4 and 1 (each within the scatter of the next). At a limit, above all of these: compound 3.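

In this assay, exchanging the side chain gives a 1.2-fold lower number from compound 1 to compound 4 (0.09 log units; within the scatter), so this pair shows no measurable difference between the two groups on a saturated chain carbon bound to an amine nitrogen. The six-membered non-aromatic ring of piperidin-4-yl and its hydrogen-bond donor can therefore give way to the ring-free 2,2-diethoxyethyl, which has no hydrogen-bond donor, without moving the number beyond the scatter, something the earlier step, made at the end of a different side chain, could not show. Nothing measured here explains why the two groups read alike.

On these data alone, this rests on a single pair, so it remains open whether the same holds for other groups at this place. A primary amine, a carboxylic acid or a longer unbranched alkyl chain could each read differently here.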